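A few compounds are considered here, and "the series" means these few. Any claim that something is new, unique, unknown or untested is made for them only; others in the source may bear on it.

Measured compounds: compound 1 `Nc1cc(N)c2nc(-c3ccccc3)c(NCc3ccc(F)cc3)nc2c1` gives 8130 nM in a functional assay on OVCAR-4 cells (Homo sapiens) for inhibition, read by sulforhodamine B assay, with a stated time of 48 h; on this read-out higher numbers stand for weaker inhibition of growth and lower numbers for stronger inhibition of growth; compound 2 `COc1ccc(CNc2nc3cc(N)cc(N)c3nc2-c2ccccc2)cc1` gives 21400 nM in this assay; compound 3 `COc1ccc(Sc2nc3cc(N)cc(N)c3nc2-c2ccccc2)cc1` is the third.

Compound 3 reaches only a limit of this assay, < 100000 nM, so where it stands against the other two cannot be read (the limit of < 100000 nM in this assay, at which 1 of the 3 values shown sits). Compound 4 `Nc1cc(N)c2nc(-c3ccccc3)c(Oc3ccc(F)cc3)nc2c1` differs from it by 4-fluorophenoxy in place of (4-methoxyphenyl)sulfanyl on an aromatic carbon. Of the measured steps, a step that the limit leaves unreadable from compound 1 to compound 3 and a 2.6-fold higher number from compound 1 to compound 2 (0.42 log units; beyond the scatter) touch a different change; neither bears directly on this one. The expectation for compound 4 therefore rests on its closeness to compound 1, and the step it implies, a step that the limit leaves unreadable from compound 3 to compound 4, is an estimate that cannot be anchored to a limit. Compound 4 is expected at 20000 nM, within 5000 nM and 80000 nM.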

Compound 4, concentration for total growth inhibition: 35500 nM
Compound 4: the middle estimate sits 1.8-fold (0.25 log units) below what was measured; low and high end bracket the measured number.
By their numbers in this assay, from the lowest: compound 1; then compounds 2 and 4 (each within the scatter of the next).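

In this assay, for the compounds shown here, the earlier compounds changed only the group on the far ring of the (benzyl)amino side chain; here the link to that ring changes while the fluoro stays, giving a 4.4-fold higher number from compound 1 to compound 4 (0.64 log units; beyond the scatter). So this position responds to the link itself, and (4-fluorobenzyl)amino gives the lower number of this pair. The step involving compound 3 cannot be read, because compound 3 stands at a limit: the limit of < 100000 nM in this assay, at which 1 of the 4 values shown sits.

On these data alone, what a longer chain, such as 2-(4-fluorophenyl)ethylamino, or a morpholine would give at this position stays open.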